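Removing a methyl from the hydroxy-methoxyphenyl ester

The source may report more compounds than this note shows. Statements on the series, on what has been measured and on what is new or still open speak of the compounds shown alone.

Compound 2, `COc1cccc(C(=O)OC/C=C(C)/C=C/C=C(C)/C=C/C2=CCCCC2(C)C)c1O`, gives 38.1% in an assay on B16-F10 cells for inhibition of Tyrosinase (Mus musculus), tested at 5 uM (a higher number here means more inhibition at the concentration tested (going by the name of the read-out), a lower number less inhibition), the lower of the two numbers seen so far. Compound 1, `CC(/C=C/C1=CCCCC1(C)C)=C\C=C\C(C)=C\COC(=O)c1cc(O)c(O)c(O)c1`, gives 49.6%; the step of a number 11.5 percentage points lower from compound 1 to compound 2 (beyond the scatter) came with the change from 3,4,5-trihydroxyphenyl to 2-hydroxy-3-methoxyphenyl. Compound 3, `CC(/C=C/C1=CCCCC1(C)C)=C\C=C\C(C)=C\COC(=O)c1cccc(O)c1O`, differs from compound 2 by hydrogen in place of methyl on an oxygen on an aromatic ring, so 2-hydroxy-3-methoxyphenyl becomes 2,3-dihydroxyphenyl. Among the compounds with values here, only that one step bears on this change, and it points toward more free hydroxy groups giving more inhibition. For compound 3 a modest rise is therefore expected, a number 6.9 percentage points higher from compound 2 to compound 3 (within the scatter). Compound 3 is estimated at 45%, with a range from 33% to 57%.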

Compound 3, a percentage reported as inhibition, at one concentration (the size of the read-out at that concentration, not a potency): 36.7%
Compound 3: middle estimate off by 8.3 percentage points, on the high side; measured number inside the range.
By their numbers in this assay, from the lowest: compounds 3 and 2 (each within the scatter of the next); then compound 1.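

The step of a number 1.4 percentage points lower from compound 2 to compound 3 (within the scatter) in this assay shows that methoxy and hydroxy cannot be told apart at this place, so freeing this oxygen brings no clear gain. The step of a number 12.9 percentage points lower from compound 1 to compound 3 (beyond the scatter) shows that 2,3-dihydroxyphenyl, like 2-hydroxy-3-methoxyphenyl, stays short of 3,4,5-trihydroxyphenyl. No evidence at hand explains either result.

Still open, on these data alone, is whether a larger group on this oxygen, such as benzyloxy, or an amine in place of it would shift the number, and whether the edge of 3,4,5-trihydroxyphenyl depends on how many hydroxy groups the ring carries or on where they sit.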